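Cyclopentylmethyl Replaces Trifluoromethylphenyl on the Amide Carbonyl

The source may report more compounds than this note shows. Statements on the series, on what has been measured and on what is new or still open speak of the compounds shown alone.

Compound 1 `O=C(Nc1cc(-c2ccccc2)nn1-c1ccccc1)c1cccc(C(F)(F)F)c1` is measured in an assay on HEK293 cells for displacement of a labelled ligand from metabotropic glutamate receptor 5 (Rattus norvegicus); on this read-out lower numbers stand for stronger inhibition and higher numbers for weaker inhibition; in this assay compound 1 gives 1650 nM. That is the lowest of the two numbers shown, and the nearest is compound 3 `COc1cccc(-n2nc(-c3ccccc3)cc2NC(=O)c2ccccc2)c1`, which in this assay gives 2100 nM, a gap within the scatter. Compound 2 `O=C(Nc1cc(-c2ccccc2)nn1-c1ccccn1)c1ccccc1` in this assay reaches only the limit > 10000 nM, so no number is known for it. Going by the values given here, the single step among the measured compounds, an at least 4.7-fold lower number from compound 2 to compound 3 (0.67 log units; beyond the scatter), changes the group on the aromatic nitrogen and says nothing about the carbonyl side. Compound 4 `O=C(CC1CCCC1)Nc1cc(-c2ccccc2)nn1-c1ccccc1` differs from compound 1 on that carbonyl carbon: cyclopentylmethyl in place of 3-(trifluoromethyl)phenyl on a carbonyl carbon. Among the compounds with values here, no measured step touches this position, so the size of the effect cannot be read from the three compounds; the aromatic ring here is one of the few remaining features shared with the other measured anilides, and a weaker binding, with a higher number beyond the scatter, is the more likely outcome. Compound 4 is therefore expected to give about 4500 nM in this assay, between 1200 nM and 15000 nM. This estimate corresponds to an expected step of a 2.7-fold higher number from compound 1 to compound 4 (0.44 log units; beyond the scatter).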

Compound 4, inhibition constant: > 10000 nM
Compound 4 was reported as a limit (the forecaster's own chance of this, stated with the estimate: 30%); middle value at least 2.2-fold (0.34 log units) away from the limit.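

Going by these compounds alone, the carbonyl side now has a measured step in this assay, an at least 6.0-fold higher number from compound 1 to compound 4 (0.78 log units; beyond the scatter), whereas the only earlier step changed the group on the aromatic nitrogen. This shows that the position is not indifferent to the group it carries: with cyclopentylmethyl in place of 3-(trifluoromethyl)phenyl on a carbonyl carbon, binding weakens beyond the scatter. Compound 4 gives a limit and not a number, so the step has only a lower bound: the limit of > 10000 nM in this assay, at which 2 of the 4 values shown sit.

The change removes the aromatic ring and the trifluoromethyl group together, so the step does not tell which of the two matters. From the compounds shown here alone, how a cyclohexyl ring, a benzyl group or a longer alkyl chain would behave on this carbonyl carbon remains open.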